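The source may report more compounds than this note shows. Statements on the series, on what has been measured and on what is new or still open speak of the compounds shown alone.

Working notes on the series, all read in a functional assay on MDA-MB-435 cells (Homo sapiens) for inhibition; on this read-out higher numbers stand for weaker inhibition and lower numbers for stronger inhibition. Compound 1 `COc1cc[nH]c1/C=C1\C(=O)Nc2ccc(F)c(I)c21`, the iodo compound, reads > 30000 nM, which is a limit of the assay and not a number. For the measured compounds named here, only two compounds give actual numbers: compound 2 `COc1cc[nH]c1/C=C1\C(=O)Nc2ccc(F)c(C#C[C@H](C)O)c21` at 190 nM and compound 3 `CN[C@@H](C#Cc1c(F)ccc2c1/C(=C/c1[nH]ccc1OC)C(=O)N2)CO` at 300 nM. These two sit within the scatter of each other, with a 1.6-fold higher number from compound 2 to compound 3 (0.20 log units; within the scatter).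

Next is compound 4 `COc1cc[nH]c1/C=C1\C(=O)Nc2ccc(F)c(C#C[C@H](CO)NCCO)c21`, which has 2-hydroxy-1-((2-hydroxyethyl)amino)ethyl in place of 1-hydroxyethyl on a triple-bonded carbon. Going by the values given here, no measured compound carries this exact group.

The large steps, an at least 150-fold lower number from compound 1 to compound 2 (2.19 log units; beyond the scatter) and an at least 100-fold lower number from compound 1 to compound 3 (2.00 log units; beyond the scatter), both replace iodo and so bear only indirectly. Compound 4 keeps the triple-bonded chain that both of those steps introduce. Among the compounds with values here, the closest precedent is the change to compound 3 at the same carbon, and a 1.6-fold higher number from compound 2 to compound 3 (0.20 log units; within the scatter) stayed within the scatter. A similar outcome is therefore expected, with a small shift towards a higher number and no step beyond the scatter in this assay. The expected step is a 1.8-fold higher number from compound 2 to compound 4 (0.27 log units; within the scatter). For compound 4 the estimated value is 350 nM, with an expected range from 120 nM to 1000 nM.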

Compound 4, half-maximal inhibitory concentration: 1270 nM
The estimate for compound 4 lay 3.6-fold (0.56 log units) below the measured number, outside the stated range (above it).
By their numbers in this assay, from the lowest: compounds 2 and 3 (each within the scatter of the next); then compound 4. At a limit, above all of these: compound 1.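

In this assay, this triple-bonded carbon proves sensitive to the group it carries: 2-hydroxy-1-((2-hydroxyethyl)amino)ethyl gives a 6.7-fold higher number from compound 2 to compound 4 (0.83 log units; beyond the scatter) and a 4.2-fold higher number from compound 3 to compound 4 (0.63 log units; beyond the scatter), both beyond the scatter, whereas 2-hydroxy-1-(methylamino)ethyl stayed within it in a 1.6-fold higher number from compound 2 to compound 3 (0.20 log units; within the scatter), so compound 3 and compound 4, which share the hydroxy-amino chain and differ only in what sits on its amine, are now separated. The chain of compound 4 still retains a large part of what the triple-bonded chains brought over the iodo group, with an at least 23-fold lower number from compound 1 to compound 4 (1.37 log units; beyond the scatter). Compound 1 is held at a limit of the assay, which is not a number, so that step has no fixed size: the limit of > 30000 nM in this assay, at which 1 of the 4 values shown sits.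

Open, on these data alone, is whether an ethylamino group, which carries the same chain length on the amine without the terminal hydroxyl, would read with compound 3 or with compound 4. Also open, as far as these compounds go, is how an unsubstituted amine, a longer hydroxyalkyl chain on the amine, or a carboxylic acid at the end of that chain would read at this carbon.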